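Cytotoxicity notes: oxadiazole to ethoxycarbamoyl exchange

This account rests on a few compounds, and the source may have more. Where it says the series, first, only, none or still open, it means among the compounds named here.

Compound 1 `CC(CCOc1ccc(-c2noc(C(C)(C)C)n2)cc1)CCN1CCN(c2ccnc(N)c2)C1=O` is the reference point. In an ADME assay on RD cells (Homo sapiens) for cytotoxicity, read by MTT assay, with a stated time of 24 h (on this read-out lower numbers stand for higher toxicity in this test and higher numbers for lower toxicity in this test), compound 1 gives 55000 nM, the higher of the two numbers shown. Compound 3 `CCc1nc(-c2cc(C)c(OCCC(C)CCN3CCN(c4ccnc(N)c4)C3=O)c(C)c2)no1` gives 15700 nM in this assay, a gap beyond the usual scatter. Compound 2 `CCO/N=C/c1ccc(OCCC(C)CCN2CCN(c3cccc(N)c3)C2=O)cc1` reaches only a limit of this assay, > 100000 nM. Of the three values shown, one sits at that limit (the limit of > 100000 nM in this assay, at which 1 of the 3 values shown sits).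

Compound 4 `CCONC(=O)c1ccc(OCCC(C)CCN2CCN(c3ccnc(N)c3)C2=O)cc1` is not yet measured in this assay. It differs from compound 1 by ethoxycarbamoyl in place of 5-(tert-butyl)-1,2,4-oxadiazol-3-yl on an aromatic carbon. Going by the values given here, no measured pair isolates this change. Compound 2 likewise carries no oxadiazole and in this assay sits at a limit. The expected step is a 1.8-fold higher number from compound 1 to compound 4 (0.26 log units; within the scatter), beyond the scatter toward a higher number. The estimate for compound 4 in this assay is 100000 nM, ranging from 40000 nM to 250000 nM.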

Compound 4, half-maximal cytotoxic concentration: > 100000 nM
Compound 4: no number, only a limit (the forecaster's own chance of this, stated with the estimate: 45%); the middle value sits exactly at the limit.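

Ethoxycarbamoyl in place of 5-(tert-butyl)-1,2,4-oxadiazol-3-yl, on an aromatic carbon para to a large group, gives the only measured pair for this change in this assay: an at least 1.8-fold higher number from compound 1 to compound 4 (0.25 log units; that floor lies within the scatter). As far as these compounds go, the value of compound 4 is a limit, not a number, so this step is only a floor and its full size stays unknown. Limit values now recur in this assay: the limit of > 100000 nM in this assay, at which 2 of the 4 values shown sit.

From the compounds shown here alone, how a carboxylic acid or a plain amide on this carbon would read remains open. Going by these compounds, whether the ethoxy part of ethoxycarbamoyl contributes to the step also remains open.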